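Cyclohexyl to benzyl on the amide-type nitrogen

The source may report more compounds than this note shows. Statements on the series, on what has been measured and on what is new or still open speak of the compounds shown alone.

Compound 1 `COc1ccc(CNC(=O)c2nc(Br)c3cccnc3c2N[C@H]2CC[C@H](N)CC2)cc1`: 4000 nM
Compound 2 `N[C@H]1CC[C@H](Nc2c(C(=O)NCc3ccc(Cl)cc3)nc(Br)c3cccnc23)CC1`: 1000 nM
Compound 3 `N[C@H]1CC[C@H](Nc2c(C(=O)NC3CCCCC3)nc(Br)c3cccnc23)CC1`: 5200 nM

These numbers come from a functional assay on HEY cells (Homo sapiens) for cytotoxicity, read by MTT assay, with a stated time of 72 h; a lower number here means a stronger inhibitor, a higher number a weaker inhibitor. Compound 3 , which carries cyclohexyl on the amide-type nitrogen, stands level with the 4-methoxybenzyl compound but apart from the 4-chlorobenzyl one. The measured steps read a 1.3-fold higher number from compound 1 to compound 3 (0.11 log units; within the scatter) and a 5.2-fold higher number from compound 2 to compound 3 (0.72 log units; beyond the scatter).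

The next compound is compound 4 `N[C@H]1CC[C@H](Nc2c(C(=O)NCc3ccccc3)nc(Br)c3cccnc23)CC1`, still unmeasured. The change is benzyl in place of cyclohexyl on an amide-type nitrogen. Compound 4 has neither the chloro nor the methoxy of its two benzyl relatives, whose values are separated by a 4.0-fold lower number from compound 1 to compound 2 (0.60 log units; beyond the scatter). Taking those two as bounds is an assumption, since no unsubstituted benzyl has been measured. On that basis a modest step toward a lower number is expected, and its size is estimated as a 2.6-fold lower number from compound 3 to compound 4 (0.41 log units; beyond the scatter). For compound 4 the estimated value is 2000 nM, with an expected range from 800 nM to 5000 nM.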

Compound 4, half-maximal inhibitory concentration: 8000 nM
Compound 4: the middle estimate sits 4.0-fold (0.60 log units) below what was measured, and the stated range ends below it.
By their numbers in this assay, from the lowest: compound 2; then compounds 1, 3 and 4 (each within the scatter of the next).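

In this assay, benzyl in place of cyclohexyl on the amide-type nitrogen leaves the two compounds level (a 1.5-fold higher number from compound 3 to compound 4 (0.19 log units; within the scatter)), so the benzyl group alone does not reproduce the stronger value of compound 2. The chloro marks that compound out: hydrogen in its place gives a clear loss (an 8.0-fold higher number from compound 2 to compound 4 (0.90 log units; beyond the scatter)), whereas hydrogen in place of methoxy leaves the compounds level (a 2.0-fold higher number from compound 1 to compound 4 (0.30 log units; within the scatter)), making the 4-chlorobenzyl compound the only one of the three benzyl compounds that stands apart. Nothing measured here accounts for this difference.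

On these data alone, it remains open whether a bromo or trifluoromethyl group on that aromatic carbon would match the chloro. The compounds also do not show whether a phenethyl group on the amide-type nitrogen would keep its effect.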